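This account rests on a few compounds, and the source may have more. Where it says the series, first, only, none or still open, it means among the compounds named here.

Measured in a functional assay on MKN-45 cells (Homo sapiens) for cytotoxicity, read by MTT assay, with a stated time of 72 h; on this read-out higher numbers stand for weaker inhibition and lower numbers for stronger inhibition:
compound 1 `COc1cc2c(Oc3ccc(NC(=O)c4cn(-c5ccccc5C)nn4)cc3F)ccnc2cc1OCCCN1CCCCC1`: 3250 nM
compound 2 `COc1cc2c(Oc3ccc(NC(=O)c4cn(-c5c(C)cccc5C)nn4)cc3F)ccnc2cc1OCCCN1CCCCC1`: 2140 nM
compound 3 `COc1cc2c(Oc3ccc(NC(=O)c4cn(-c5ccc(F)c(F)c5)nn4)cc3F)ccnc2cc1OCCCN1CCCCC1`: 310 nM

Compound 3 stands lowest of the three numbers, with the steps of a 10-fold lower number from compound 1 to compound 3 (1.02 log units; beyond the scatter) and a 6.9-fold lower number from compound 2 to compound 3 (0.84 log units; beyond the scatter) both beyond the scatter, whereas a 1.5-fold lower number from compound 1 to compound 2 (0.18 log units; within the scatter) stays within it. Compound 4 `COc1cc2c(Oc3ccc(NC(=O)c4cn(-c5ccc(F)c(F)c5)nn4)cc3F)ccnc2cc1OCCCN1CCN(C)CC1` differs from compound 3 by 4-methylpiperazin-1-yl in place of piperidin-1-yl on a saturated chain carbon, three bonds along the chain from an oxygen on an aromatic ring. Going by the values given here, none of the measured steps bears on this part of the molecule; all three alter the group on the aromatic nitrogen, and the chain end is the same in compounds 1, 2 and 3. With nothing to suggest a shift, no step beyond the scatter in this assay is expected, which is the estimate a 1.0-fold lower number from compound 3 to compound 4 (0.01 log units; within the scatter). Compound 4 is therefore expected to give about 300 nM, estimated between 120 nM and 800 nM.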

Compound 4, half-maximal inhibitory concentration: 160 nM
Compound 4: the middle estimate sits 1.9-fold (0.27 log units) above what was measured; measured number inside the range.
By their numbers in this assay, from the lowest: compounds 4 and 3 (each within the scatter of the next); then compounds 2 and 1 (each within the scatter of the next).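

Where the earlier compounds varied only the group on the aromatic nitrogen, this pair changes the chain end: in this assay, 4-methylpiperazin-1-yl in place of piperidin-1-yl gives a 1.9-fold lower number from compound 3 to compound 4 (0.29 log units; within the scatter). With the 3,4-difluorophenyl group in place, this position therefore accepts the change without a step beyond the scatter. No measurement at hand offers an explanation for this result.

On these data alone, whether the change behaves alike with the 2-methylphenyl group of compound 1 remains open. So does the outcome for a morpholine or a dimethylamino group at the chain end, or for a longer chain.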